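Dihydroxyphenyl Swap on a Nitro-Bearing Bicyclic Core

The source may hold more compounds than are shown below. What is called first, only, known or untested is meant among the compounds shown, and "the series" means these compounds.

The first pair shares a core that carries a trifluoromethyl group. Compound 1 `O=[N+]([O-])C1=NNc2nc(C(F)(F)F)nn2C1c1ccc(O)c(O)c1` is tested in an ADME assay on MDCK cells (Canis lupus familiaris) for cytotoxicity (a lower number here means that less compound is tolerated, a higher number that more compound is tolerated), where compound 1 gives 183000 nM. Compound 2 `O=[N+]([O-])C1=NNc2nc(C(F)(F)F)nn2C1c1ccc(O)cc1O` gives 108000 nM in this assay. The change between them is 2,4-dihydroxyphenyl in place of 3,4-dihydroxyphenyl on a saturated ring carbon, and it makes the step of a 1.7-fold lower number from compound 1 to compound 2 (0.23 log units; within the scatter), which the scatter covers.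

Compound 3 `O=[N+]([O-])C1=CNc2nc(-c3ccco3)nn2C1c1ccc(O)c(O)c1` carries a furanyl group on its core instead. In this assay compound 3 reaches only a limit, > 1200000 nM, and no number is obtained for it. The difference between the core of compound 3 and the core of compound 1 is not broken down here. Compound 4 `O=[N+]([O-])C1=CNc2nc(-c3ccco3)nn2C1c1ccc(O)cc1O` is not yet measured. It is reached from compound 3 by 2,4-dihydroxyphenyl in place of 3,4-dihydroxyphenyl on a saturated ring carbon. For the measured compounds named here, this is the same kind of change as the one from compound 1 to compound 2, though the surroundings differ: in compound 1 the saturated ring carbon sits in a six-membered non-aromatic ring with 3 nitrogen, two ring bonds from the ring nitrogen, while in compound 3 that ring has 2 nitrogen.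

The step for compound 4 is expected to be a number no higher from compound 3 to compound 4 (the limit leaves the size open), beside the earlier 1.7-fold lower number from compound 1 to compound 2 (0.23 log units; within the scatter), resting on that step lying within the scatter and on compound 3 already sitting at the limit of > 1200000 nM in this assay, at which 1 of the 3 values shown sits. Compound 4 is thus estimated at 1200000 nM, between 500000 nM and 2400000 nM, most likely again reported only as a limit.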

Compound 4, half-maximal cytotoxic concentration: 119000 nM
Beside the measured number, compound 4's estimate is 10-fold (1.00 log units) above it; the measured number lies below the stated range.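

Taking 2,4-dihydroxyphenyl in place of 3,4-dihydroxyphenyl on the saturated ring carbon gives an at least 10-fold lower number from compound 3 to compound 4 (1.00 log units; beyond the scatter) in this assay, so the change cannot be carried from one core to the other at its earlier size: the same change on two cores in this assay, a 1.7-fold lower number (0.23 log units; within the scatter) from compound 1 to compound 2 and an at least 10-fold lower number (1.00 log units; beyond the scatter) from compound 3 to compound 4, at least 5.9-fold (0.77 log units) apart, beyond the scatter of two such steps. Compound 3 stands at a limit and not at a number, so this step and the gap between the two steps give only a smallest size: the limit of > 1200000 nM in this assay, at which 1 of the 4 values shown sits. The two cores differ in more than one place, trifluoromethyl against furanyl and the count of nitrogen in the ring that holds the saturated carbon, so the two pairs do not show which of these differences goes with the gap, and two pairs make no rule for the whole series.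

The compounds shown leave open whether a core that joins the furanyl group to the ring with 3 nitrogen, or the trifluoromethyl group to the ring with 2 nitrogen, would follow compound 1 or compound 3 in this swap. They also leave open how the same swap behaves with an amine or a carboxylic acid in the place of the trifluoromethyl or furanyl group.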